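Adding One Methoxy Group to Compound 2: an Expected Value

The compounds below may be only part of what the source reports. "The series", "measured", "known", "first", "only" and "open" are said of these compounds alone.

Measured compounds:
compound 1, `COc1cc(-c2cc(/C=C/C(=O)c3ccc(N)cc3)[nH]n2)cc(OC)c1OC`, 92%
compound 2, `COc1ccc(C(=O)/C=C/c2cc(-c3cc(OC)c(OC)c(OC)c3)n[nH]2)cc1OC`, 96%
compound 3, `COc1ccc(-c2cc(/C=C/C(=O)c3ccc(N)cc3)[nH]n2)cc1OC`, 91%

All three were tested in a functional assay on 786-0 cells (Homo sapiens) for cytotoxicity, read by sulforhodamine B assay, with a stated time of 48 h, tested at 0.01 uM; on this read-out lower numbers stand for a stronger effect and higher numbers for a weaker effect at the one concentration tested. Compound 1 differs from compound 3 by methoxy in place of hydrogen on an aromatic carbon, and the measured step is a number 1 percentage points higher from compound 3 to compound 1 (within the scatter). Compound 2 differs from compound 1 in another place, with the step of a number 4 percentage points higher from compound 1 to compound 2 (within the scatter). Compound 2 and compound 3 differ in more than one place, so the difference between their cores is not broken down here.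

Compound 4, `COc1cc(C(=O)/C=C/c2cc(-c3cc(OC)c(OC)c(OC)c3)n[nH]2)cc(OC)c1OC`, is not yet measured. It differs from compound 2 by methoxy in place of hydrogen on an aromatic carbon, the same change as from compound 3 to compound 1, at a place described in the same words. Because the measured step was a number 1 percentage points higher from compound 3 to compound 1 (within the scatter), the expected step is no change at the digits printed from compound 2 to compound 4 (within the scatter). Compound 4 is therefore estimated at 96% in this assay.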

Compound 4, a percentage reported as activity, at one concentration (the size of the read-out at that concentration, not a potency): 101%
The estimate for compound 4 lay 5 percentage points below the measured number, and the stated range covers the measured number.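

Swapping hydrogen for methoxy on an aromatic carbon gives a number 5 percentage points higher from compound 2 to compound 4 (within the scatter) in this assay. Set beside the earlier case, the two steps do not differ on the two cores: the same change on two cores in this assay, a number 1 percentage points higher (within the scatter) from compound 3 to compound 1 and a number 5 percentage points higher (within the scatter) from compound 2 to compound 4, 4 percentage points apart, within the scatter of two such steps. This shows that the change carries from one core to the other without a detectable difference at this one concentration, but it does not show that methoxy has any real effect on either core, and it says nothing about other concentrations.

The compounds shown leave open whether a different group at this place, such as a hydroxyl group or a carboxylic acid, would give a step beyond the scatter.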